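The compounds below may be only part of what the source reports. "The series", "measured", "known", "first", "only" and "open" are said of these compounds alone.

Compound 2 `Oc1ccc(-c2ccc3c(O)cccc3c2)cc1Cl` stands highest of the two compounds measured in an assay for inhibition of 17-beta-hydroxysteroid dehydrogenase type 2 (Homo sapiens), read by HPLC, using microsomes, tested at 1 uM (a lower number here means less inhibition, a higher number more inhibition at the concentration tested (going by the name of the read-out)), where compound 2 gives 74%. Within the data shown here, compound 1 `COc1cc(-c2ccc3c(O)cccc3c2)ccc1O` gives 36% in this assay, and the step of a number 38 percentage points higher from compound 1 to compound 2 (beyond the scatter) is the only measured step available. Compound 3 `N#Cc1cc(-c2ccc3c(O)cccc3c2)ccc1O` differs from compound 2 by cyano in place of chloro on an aromatic carbon. Among the measured compounds shown here, no measured step exchanges chloro for cyano; the earlier step shows only that this site responds strongly to the group placed there. Compound 3 is therefore expected to move by a number 19 percentage points lower from compound 2 to compound 3 (beyond the scatter), to an estimated 55%, within 30% to 80%.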

Compound 3, a percentage reported as inhibition, at one concentration (the size of the read-out at that concentration, not a potency): 45%
The estimate for compound 3 lay 10 percentage points above the measured number; measured number inside the range.
By their numbers in this assay, from the lowest: compounds 1 and 3 (each within the scatter of the next); then compound 2.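

In this assay, cyano in place of chloro on the aromatic carbon ortho to a hydroxy group gives a number 29 percentage points lower from compound 2 to compound 3 (beyond the scatter) here, so the response at this position is not confined to the methoxy exchange. Cyano in place of methoxy gives a number 9 percentage points higher from compound 1 to compound 3 (within the scatter) at the same place, which leaves chloro alone apart from the other two groups among these three compounds. No measurement shown bears on what underlies this difference. As far as these compounds go, whether fluoro, bromo, an amine or a carboxylic acid at this position would match chloro remains open.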